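Hydroxy to Methoxy on a Second Core: Expected Half-Life

This account rests on a few compounds, and the source may have more. Where it says the series, first, only, none or still open, it means among the compounds named here.

Compound 1, `O=C1/C(=N/O)c2ccncc2N1Cc1nc2ccccc2n1CCCCF`: 1.67 h
Compound 2, `N#CCCCn1c(CN2C(=O)/C(=N/O)c3cccnc32)nc2ccccc21`: 1.67 h
Compound 3, `CO/N=C1/C(=O)N(Cc2nc3ccccc3n2CCCCF)c2cnccc21`: 0.433 h

These three compounds have been measured in an ADME assay on liver (Homo sapiens) for metabolic stability; on this read-out lower numbers stand for a shorter-lived compound and higher numbers for a longer-lived compound. Compound 1 and compound 3 differ in one place only: methyl in place of hydrogen on an oxygen. That single change gave a 3.9-fold lower number from compound 1 to compound 3 (0.59 log units; beyond the scatter), so the methylated compound is cleared noticeably faster by liver material.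

Compound 2 carries the same hydrogen on oxygen as compound 1, but its core is built differently; the difference between the two cores is not broken down here. In this assay compound 2 and compound 1 give numbers that lie within the usual scatter of each other, so they cannot be told apart.

Compound 4, `CO/N=C1/C(=O)N(Cc2nc3ccccc3n2CCCC#N)c2ncccc21`, has not yet been measured. Its relation to compound 2 is exactly the change seen between compound 1 and compound 3: methyl in place of hydrogen on an oxygen. The place of the change reads the same word for word in both pairs, so it is the same change, only on a different core.

Going by the values given here, because a 3.9-fold lower number from compound 1 to compound 3 (0.59 log units; beyond the scatter) is the only guide available, the step is expected to be about as large, namely a 3.7-fold lower number from compound 2 to compound 4 (0.57 log units; beyond the scatter), with the caveat that a single pair is a thin basis. Compound 4 is therefore expected to give roughly 0.45 h in this assay. The estimate for compound 4 is thought to span from 0.2 h to 1 h.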

Compound 4, half-life: 0.467 h
For compound 4 the middle estimate is 1.0-fold (0.02 log units) below the measured one; the range from low to high includes it.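

In this assay, putting methoxy in place of hydroxy on the second core gave a 3.6-fold lower number from compound 2 to compound 4 (0.55 log units; beyond the scatter), and this step matches the earlier one closely: the same change on two cores in this assay, a 3.9-fold lower number (0.59 log units; beyond the scatter) from compound 1 to compound 3 and a 3.6-fold lower number (0.55 log units; beyond the scatter) from compound 2 to compound 4, 1.1-fold (0.03 log units) apart, within the scatter of two such steps

This shows that, across these two pairs, the change carried from one core to the other with its size intact, so the step measured on the first core was a fair guide for the second. It does not show that the change would behave the same way on any other core, since two pairs are a small sample, and the two pairs also differ in their side chain, one ending in fluorine and the other in a nitrile. Nor does it explain why the number falls, or which part of each molecule the liver material acts on.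

The compounds shown leave open what a larger group on that same oxygen would do, such as an ethyl group or a longer chain ending in an amine. They also leave open whether the step would keep its size with other side chains on these two cores, such as a plain butyl chain with no fluorine or nitrile.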